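Inverting One Ring Stereocentre in an Inactive Phosphoserine Ester

The compounds below may be only part of what the source reports. "The series", "measured", "known", "first", "only" and "open" are said of these compounds alone.

Compound 2 `N[C@@H](COP(=O)(O)OC[C@H]1OCCC[C@@H]1OC(=O)CCc1ccccc1OCc1cccc(Oc2ccccc2)c1)C(=O)O` is one of three measured members of a small set of phosphoserine-linked esters tested in an assay on HEK293-A cells with putative P2Y purinoceptor 10 (Mus musculus) as the target, with a stated time of 1.5 h; a higher number here means a larger maximal response, a lower number a smaller maximal response. In this assay compound 2 gives "not active" (no number reported), and no number stands behind that outcome. A closely related compound 1 `N[C@@H](COP(=O)(O)O[C@@H]1CCCO[C@@H]1COC(=O)CCc1ccccc1OCc1cccc(Oc2ccccc2)c1)C(=O)O` fares no differently: in this assay compound 1 gives "not active" (no number reported). Among the measured compounds shown here, the only member with a numerical result is compound 3 `CCCCCCCCCCCOc1ccccc1CCC(=O)OC[C@H]1OCCC[C@@H]1OP(=O)(O)OC[C@H](N)C(=O)O`, which in this assay gives 0.002, a maximal response barely distinguishable from none. Compound 2 therefore stands among compounds that show either no response or one at the floor of the measurement.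

Compound 4 `N[C@@H](COP(=O)(O)OC[C@H]1OCCC[C@H]1OC(=O)CCc1ccccc1OCc1cccc(Oc2ccccc2)c1)C(=O)O` differs from compound 2 in a single respect: the two compounds have the same atoms and bonds; at least one stereo element is drawn with a configuration in one of them and without one in the other: 1 of 4 stereo elements differ; a stereocentre at a saturated ring carbon is drawn S in compound 2 and R in compound 4. For the measured compounds named here, no step between two measured compounds is available here, so there is no precedent for what such an inversion does in this assay. With all three neighbours at or near the floor, no move beyond the usual scatter is expected, in either direction. Compound 4 is expected to give 0.02, within a range from 0 to 0.12.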

Compound 4, intrinsic activity: the largest response reached, as a fraction of the reference agonist's: "not active" (no number reported)
Compound 4: no number reported, and the estimate cannot be compared.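

In this assay, among the compounds shown here, compound 2 and compound 4 both come out as not active, with no number reported, so no step between them can be read. What the inversion at the saturated ring carbon does to the maximal response stays open, and the pair offers only this to go on: the fact that one of compounds 2 and 4 is drawn with a defined configuration and the other without, at the place where they differ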